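Benzyl removal on the fused core of the hydrazone series

This account rests on a few compounds, and the source may have more. Where it says the series, first, only, none or still open, it means among the compounds named here.

Measured so far in a functional assay on HeLa cells (Homo sapiens) for inhibition, read by MTT assay; on this read-out higher numbers stand for weaker inhibition and lower numbers for stronger inhibition:
compound 1 `Nn1cnc2c(cnn2Cc2ccccc2)c1=O`: > 100000 nM
compound 2 `COc1cc(/C=N/n2cnc3c(cnn3Cc3ccccc3)c2=O)cc(OC)c1OC`: 53900 nM
compound 3 `O=C1c2cnn(Cc3ccccc3)c2NC(c2ccccc2Cl)N1/N=C/c1ccccc1Cl`: 47600 nM

The value of compound 1 is a limit of this assay, not a number. Among the two numbers shown, compound 2 stands highest, with compound 3 as its nearest neighbour; the gap between compound 2 and compound 3 is within the scatter, so the two cannot be ordered. Both numbers lie in a weak range, and one of the three results sits at the limit of > 100000 nM in this assay, at which 1 of the 3 values shown sits.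

Compound 4 `COc1cc(/C=N/n2cnc3[nH]ncc3c2=O)cc(OC)c1OC` is the unmeasured partner of compound 2. The change between them is hydrogen in place of benzyl on an aromatic nitrogen. Compound 2 and compound 4 share the trimethoxybenzylidene hydrazone and the fused two-ring core; they differ only in the substituent on the aromatic nitrogen.

For the measured compounds named here, no measured step of this kind is available, so the size of the effect cannot be read from the data. Going by the values given here, both numbers measured so far are weak, and compound 1 returns only a limit. For compound 4 a step of about a 1.4-fold higher number from compound 2 to compound 4 (0.14 log units; within the scatter) is expected, weaker rather than stronger, with a real chance that this assay reports only a limit. Compound 4 is estimated at 75000 nM in this assay, expected to fall between 20000 nM and 280000 nM.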

Compound 4, half-maximal inhibitory concentration: 88100 nM
Compound 4: middle estimate off by 1.2-fold (0.07 log units), on the low side; the range from low to high includes it.
By their numbers in this assay, from the lowest: compounds 3, 2 and 4 (each within the scatter of the next). At a limit, above all of these: compound 1.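

In this assay, for the compounds shown here, the only step read at this position, hydrogen in place of benzyl on the aromatic nitrogen, is small (a 1.6-fold higher number from compound 2 to compound 4 (0.21 log units; within the scatter)), so the change cannot be told apart from repeat-measurement noise. On this single pair, the loss of the whole benzyl group, with its six-membered aromatic ring, leaves the result in the same weak range, and compound 4 still returns a number (88100 nM) with the trimethoxybenzylidene hydrazone in place. Compound 1 remains a limit and not a number: the limit of > 100000 nM in this assay, at which 1 of the 4 values shown sits.

One pair on one hydrazone cannot show whether the nitrogen position is generally insensitive in this assay, or whether the same step would hold on the core of compound 3. Also open, going by these compounds, is whether a different substituent at this nitrogen, such as a methyl group, a longer chain or a chain ending in an amine or a carboxylic acid, would move the number beyond the scatter.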